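Adding a Methoxy to a Weak HeLa Cell Inhibitor

The source may hold more compounds than are shown below. What is called first, only, known or untested is meant among the compounds shown, and "the series" means these compounds.

Three compounds have been measured in a functional assay on HeLa cells (Homo sapiens) for inhibition, read by MTT assay, with a stated time of 48 h; on this read-out lower numbers stand for stronger inhibition and higher numbers for weaker inhibition:
compound 1 `O=C(Nc1cnn(-c2ccccc2)c1)c1cccc(NS(=O)(=O)c2ccccc2)c1` gives 15300 nM
compound 2 `COc1cccc(-n2cc(NC(=O)c3cccc(NS(=O)(=O)c4ccccc4)c3)cn2)c1` gives 26200 nM
compound 3 `O=C(Nc1cnn(-c2ccccc2)c1)c1ccc(NS(=O)(=O)c2ccccc2)cc1` gives 37100 nM

Compound 3 carries the largest of the three numbers; its gap to compound 2 lies within the usual scatter, its gap to compound 1 beyond it. Compound 4 `COc1cccc(-n2cc(NC(=O)c3ccc(NS(=O)(=O)c4ccccc4)cc3)cn2)c1` differs from compound 3 by methoxy in place of hydrogen on an aromatic carbon. The same change is already seen once, between compound 1 and compound 2: a 1.7-fold higher number from compound 1 to compound 2 (0.23 log units; within the scatter). On that single comparison, no step beyond the scatter is expected from compound 3 to compound 4, with at most a slightly higher number, a 1.3-fold higher number from compound 3 to compound 4 (0.13 log units; within the scatter). Compound 4 is therefore estimated at 50000 nM, within a range from 20000 nM to 130000 nM.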

Compound 4, half-maximal inhibitory concentration: 66200 nM
For compound 4 the middle estimate is 1.3-fold (0.12 log units) below the measured one; measured number inside the range.
By their numbers in this assay, from the lowest: compounds 1, 2, 3 and 4 (each within the scatter of the next, the first and the last beyond it).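

Going from phenyl to 3-methoxyphenyl in this assay gives a 1.8-fold higher number from compound 3 to compound 4 (0.25 log units; within the scatter). The change has now been seen on a second core, and again it brings no lower number. Neither step alone passes the scatter, but the two agree closely, so the small upward drift seen first on one core recurs on the other: the same change on two cores in this assay, a 1.7-fold higher number (0.23 log units; within the scatter) from compound 1 to compound 2 and a 1.8-fold higher number (0.25 log units; within the scatter) from compound 3 to compound 4, 1.0-fold (0.02 log units) apart, within the scatter of two such steps

The compounds shown leave open whether an amine or a carboxylic acid on this same aromatic carbon would move the number beyond the scatter. They also leave open whether methoxy elsewhere on this ring would behave alike.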